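A few compounds are considered here, and "the series" means these few. Any claim that something is new, unique, unknown or untested is made for them only; others in the source may bear on it.

Compound 1 `COc1cc2c(cc1OC)C(CC(=O)O)CC2` and compound 2 `CCN(CC)C(=O)CC1CCc2cc(OC)c(OC)cc21` share one core and differ only in the group on the carbonyl carbon of the side chain. In a functional assay on the whole organism (strain Wistar) for inhibition, with Rattus norvegicus as the target, read by paw edema, with stated times of 60 min and 1 h, at a dose of 100 mg/kg by the oral route (on this read-out higher numbers stand for more inhibition at the one dose given (going by the name of the read-out) and lower numbers for less inhibition), compound 1 gives 18.8%. In this assay, within the data shown here, compound 2 gives 31.3%, the higher of the two numbers, and the single measured step, a number 12.5 percentage points higher from compound 1 to compound 2 (beyond the scatter), lies beyond the scatter. Compound 3 `CCCCCNC(=O)CC1CCc2cc(OC)c(OC)cc21` has not been measured; it differs from compound 2 by pentylamino in place of diethylamino on a carbonyl carbon. The measured step bears on this change only in that it also sits on the carbonyl carbon, yet it put diethylamino in place of hydroxy rather than pentylamino in place of diethylamino, so its size is a weak guide, and no step beyond the scatter is expected here. In this assay compound 3 is therefore estimated at about 30%, between 15% and 45%. The expected step is a number 1.3 percentage points lower from compound 2 to compound 3 (within the scatter), within the scatter.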

Compound 3, a percentage reported as inhibition, in the whole organism at one dose (the size of the read-out at that dose, not a potency): 34.4%
Beside the measured number, compound 3's estimate is 4.4 percentage points below it, within the range that was stated.
By their numbers in this assay, from the lowest: compound 1; then compounds 2 and 3 (each within the scatter of the next).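

In this assay, pentylamino in place of diethylamino on the carbonyl carbon gives a number 3.1 percentage points higher from compound 2 to compound 3 (within the scatter), so at this position the hydrogen-bond donor counted in pentylamino, and absent from diethylamino, goes with no readable change at the one dose tested. Pentylamino in place of hydroxy gives a number 15.6 percentage points higher from compound 1 to compound 3 (beyond the scatter), so among these three compounds both amino groups on this carbonyl carbon stand clear of the hydroxy group of compound 1, and the earlier step no longer rests on diethylamino alone. Nothing measured on these compounds accounts for either step.

Going by these compounds, it remains open whether a plain amino group, or a longer chain such as octylamino, on the same carbonyl carbon would stand apart from compound 2 and compound 3. These single-dose numbers also leave open how the compounds would compare at other doses.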